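A few compounds are considered here, and "the series" means these few. Any claim that something is new, unique, unknown or untested is made for them only; others in the source may bear on it.

In a functional assay on MDA-MB-231 cells (Homo sapiens) for antiproliferative activity, read by MTT assay, with a stated time of 72 h (a higher number here means a weaker inhibitor, a lower number a stronger inhibitor), three compounds sharing one core have been measured: compound 1 `O=C(CCc1cccc2c1B(O)OC2)Nc1cccc(Br)c1` gives 720 nM, compound 2 `O=C(CCc1cccc2c1B(O)OC2)Nc1cccc(-c2cccc(F)c2)c1` gives 570 nM, and compound 3 `O=C(CCc1cccc2c1B(O)OC2)Nc1cccc(-c2ccc(F)cc2)c1` gives 250 nM, the lowest of the three. Compound 4 `COc1ccc(-c2cccc(NC(=O)CCc3cccc4c3B(O)OC4)c2)cc1` differs from compound 3 in one place, with methoxy in place of fluoro on an aromatic carbon, para to a large group (methoxy in place of fluoro on an aromatic carbon). Going by the values given here, no measured step makes this exact swap. The closest guides are a 2.3-fold lower number from compound 2 to compound 3 (0.36 log units; beyond the scatter) and a 2.9-fold lower number from compound 1 to compound 3 (0.46 log units; beyond the scatter), both modest, while a 1.3-fold lower number from compound 1 to compound 2 (0.10 log units; within the scatter) is smaller still. With steps this small, no clear change in either direction is expected in this assay. The expected step is a 1.2-fold higher number from compound 3 to compound 4 (0.08 log units; within the scatter). Compound 4 is estimated at 300 nM, with an expected range from 120 nM to 750 nM.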

Compound 4, half-maximal inhibitory concentration: 88 nM
Compound 4: the middle estimate sits 3.4-fold (0.53 log units) above what was measured; the measured number lies below the stated range.
By their numbers in this assay, from the lowest: compound 4; then compound 3; then compounds 2 and 1 (each within the scatter of the next).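

In this assay, methoxy in place of fluoro, para to a large group, gives a 2.8-fold lower number from compound 3 to compound 4 (0.45 log units; beyond the scatter) and so shows that this position still responds to change once the second ring is present. The 4-methoxyphenyl group gives a 6.5-fold lower number from compound 2 to compound 4 (0.81 log units; beyond the scatter) and an 8.2-fold lower number from compound 1 to compound 4 (0.91 log units; beyond the scatter) as the largest steps in this set, which puts compound 4 lowest of the four. No evidence here explains the difference between methoxy and fluoro.

Going by these compounds, whether ethoxy, hydroxyl or an amine at this same position would lower the number further stays open. On these data alone, whether the step between fluoro and methoxy holds in other cell lines also stays open.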